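The compounds below may be only part of what the source reports. "The series", "measured", "known", "first", "only" and "open" are said of these compounds alone.

Compound 2 `Cc1ccc2[nH]c(-n3[nH]c(C)c(Cc4ccccc4)c3=O)nc2c1` gives 34% in a functional assay on DU-145 cells (Homo sapiens) for antiproliferative activity, read by WST assay, with a stated time of 7 days, tested at 1 uM (on this read-out lower numbers stand for a weaker effect and higher numbers for a stronger effect at the one concentration tested), the lower of the two numbers in hand; compound 1 `Cc1[nH]n(-c2nc3cc(Cl)ccc3[nH]2)c(=O)c1Cc1ccccc1` gives 84%, and the step of a number 50 percentage points lower from compound 1 to compound 2 (beyond the scatter) is the only measured one. Compound 3 `Cc1ccc2[nH]c(-n3[nH]c(C)c(C)c3=O)nc2c1` differs from compound 2 by hydrogen in place of phenyl on a saturated chain carbon bound to an aromatic carbon. Among the compounds with values here, no measured step covers this change: the step from compound 1 to compound 2 concerns another place and gives no guide to it. For compound 3 a modest further fall is expected as a working guess, about 18% (range 0% to 45%), an estimated step of a number 16 percentage points lower from compound 2 to compound 3 (beyond the scatter).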

Compound 3, a percentage reported as inhibition, at one concentration (the size of the read-out at that concentration, not a potency): 3.8%
Compound 3: the middle estimate sits 14.2 percentage points above what was measured; low and high end bracket the measured number.
By their numbers in this assay, from the lowest: compound 3; then compound 2; then compound 1.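

In this assay, the change from benzyl to methyl on the shared core gives a number 30.2 percentage points lower from compound 2 to compound 3 (beyond the scatter). The position is therefore not indifferent: the read-out at this concentration depends strongly on the phenyl on the saturated chain carbon. No data given here explain this loss.

Open, going by these compounds, is how a longer chain or a carboxylic acid in place of the benzyl would read. Also open, on these data alone, is whether the same step holds with chloro in place of methyl on the aromatic carbon, as in compound 1.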